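Aryl Replacement on a Shared Core: What Compound 4 Might Give

The compounds below may be only part of what the source reports. "The series", "measured", "known", "first", "only" and "open" are said of these compounds alone.

Of the compounds shown here, three on one core have been measured in an assay on HEK293 cells for activation of Kir3.1/Kir3.2 (Homo sapiens), read by thallium flux; on this read-out lower numbers stand for smaller maximal responses and higher numbers for larger maximal responses. Compound 1 `Cc1cc(NC(=O)Cn2nnc(-c3cccnc3)n2)n(C2CCCCC2)n1` gives 96%. Compound 2 `Cc1cc(NC(=O)Cn2nnc(-c3ccccc3F)n2)n(C2CCCCC2)n1` gives 88%, and compound 3 `Cc1cc(NC(=O)Cn2nnc(-c3ccc(F)c(F)c3)n2)n(C2CCCCC2)n1` gives 93%. Compound 3 stands second highest of the three numbers shown, with a number 3 percentage points lower from compound 1 to compound 3 (within the scatter) and a number 5 percentage points higher from compound 2 to compound 3 (within the scatter). Compound 4 `Cc1cc(NC(=O)Cn2nnc(-c3ccnc(F)c3)n2)n(C2CCCCC2)n1` differs from compound 3 by 2-fluoropyridin-4-yl in place of 3,4-difluorophenyl on an aromatic carbon. Within the data shown here, the steps that bear on this exchange of one aryl group for another are a number 8 percentage points lower from compound 1 to compound 2 (within the scatter), a number 3 percentage points lower from compound 1 to compound 3 (within the scatter) and a number 5 percentage points higher from compound 2 to compound 3 (within the scatter), none of them beyond the scatter. No step beyond the scatter is therefore expected for a number 1 percentage points lower from compound 3 to compound 4 (within the scatter) in this assay. Compound 4 is estimated at 92%, with an expected range from 80% to 102%.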

Compound 4, largest response reached (Emax), in percent of the reference or control that the assay uses: 95%
Compound 4: middle estimate off by 3 percentage points, on the low side; measured number inside the range.
By their numbers in this assay, from the lowest: compounds 2, 3, 4 and 1 (each within the scatter of the next).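

In this assay the 2-fluoropyridin-4-yl group, which carries a ring nitrogen and a fluorine on one ring, stays within the scatter of all three earlier aryl groups (a number 2 percentage points higher from compound 3 to compound 4 (within the scatter); a number 7 percentage points higher from compound 2 to compound 4 (within the scatter); a number 1 percentage points lower from compound 1 to compound 4 (within the scatter)). The maximal response at this position on the shared core therefore holds across four aryl groups, now including a fluorinated pyridine. No measurement here explains this. The compounds shown leave open whether the response would hold with a carboxylic acid or an amine in place of the aryl group.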